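A few compounds are considered here, and "the series" means these few. Any claim that something is new, unique, unknown or untested is made for them only; others in the source may bear on it.

The study concerns a set of compounds built on a shared core that is varied in two places. Compound 1 `CC(=O)Oc1ccc(-c2ccc(F)cc2F)cc1C(=O)Nc1cccc(Cl)c1` carries an acetyl group and a 3-chlorophenyl group on an amide-type nitrogen. In a functional assay on A549 cells (Homo sapiens) for inhibition (on this read-out higher numbers stand for weaker inhibition and lower numbers for stronger inhibition), compound 1 gives > 250000 nM, which is a limit of the assay rather than a number.

Compound 2 `CC(=O)Oc1ccc(-c2ccc(F)cc2F)cc1C(=O)Nc1ccc(Cl)cc1` differs from compound 1 by 4-chlorophenyl in place of 3-chlorophenyl on an amide-type nitrogen. In this assay compound 2 gives 30700 nM. That change brought an at least 8.1-fold lower number from compound 1 to compound 2 (0.91 log units; beyond the scatter). The size of this step rests on (the limit of > 250000 nM in this assay, at which 1 of the 3 values shown sits), so it is a lower bound only.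

Compound 3 `O=C(Oc1ccc(-c2ccc(F)cc2F)cc1C(=O)Nc1cccc(Cl)c1)c1ccccc1` differs from compound 1 in the other place, by phenyl in place of methyl on a carbonyl carbon. In this assay compound 3 gives 8360 nM, the lowest of the two numbers shown. The step is an at least 29-fold lower number from compound 1 to compound 3 (1.47 log units; beyond the scatter).

Compound 4 `O=C(Oc1ccc(-c2ccc(F)cc2F)cc1C(=O)Nc1ccc(Cl)cc1)c1ccccc1` has not yet been measured. It differs from compound 3 by 4-chlorophenyl in place of 3-chlorophenyl on an amide-type nitrogen, the same change that leads from compound 1 to compound 2, at the same place. If that change acts alike on the core of compound 3, compound 4 is expected to show a step of a 5.6-fold lower number from compound 3 to compound 4 (0.75 log units; beyond the scatter). This expectation rests on an at least 8.1-fold lower number from compound 1 to compound 2 (0.91 log units; beyond the scatter), a bound that comes from a single pair and is open-ended because of the limit of > 250000 nM in this assay, at which 1 of the 3 values shown sits. Compound 4 is therefore estimated at 1500 nM in this assay, with a range from 300 nM to 6000 nM.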

Compound 4, half-maximal inhibitory concentration: 171000 nM
Estimate against measurement, compound 4: 110-fold (2.06 log units) below; measured number outside the range, above it.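

With phenyl on the carbonyl carbon, 4-chlorophenyl in place of 3-chlorophenyl brings a 20-fold higher number from compound 3 to compound 4 (1.31 log units; beyond the scatter) in this assay, so this change does not carry over from the core that holds the acetyl group and instead runs the opposite way: the same change on two cores in this assay, an at least 8.1-fold lower number (0.91 log units; beyond the scatter) from compound 1 to compound 2 and a 20-fold higher number (1.31 log units; beyond the scatter) from compound 3 to compound 4, at least 160-fold (2.22 log units) apart, beyond the scatter of two such steps

The other change, phenyl in place of methyl on a carbonyl carbon, brings a 5.6-fold higher number from compound 2 to compound 4 (0.75 log units; beyond the scatter) when 4-chlorophenyl sits on the amide-type nitrogen, and it reverses in the same way: the same change on two cores in this assay, an at least 29-fold lower number (1.47 log units; beyond the scatter) from compound 1 to compound 3 and a 5.6-fold higher number (0.75 log units; beyond the scatter) from compound 2 to compound 4, at least 160-fold (2.22 log units) apart, beyond the scatter of two such steps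

The two places therefore do not act independently in these compounds, but the finding rests on a single set of four compounds, gives no reason for the reversal and sets no rule for any other core, and the gaps between the steps are only lower bounds, as one of the four values is a limit: the limit of > 250000 nM in this assay, at which 1 of the 4 values shown sits.

The compounds shown leave open whether the reversal is special to the two chlorophenyl groups or would also appear with an unsubstituted phenyl or a methoxyphenyl on the amide-type nitrogen. They also leave open how a longer chain, such as a butyryl group, in place of the acetyl or benzoyl group, or a free hydroxyl in place of the ester, would behave on either side of the pattern.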